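The compounds below may be only part of what the source reports. "The series", "measured", "known", "first", "only" and "open" are said of these compounds alone.

Measured in a functional assay on K562 cells (Homo sapiens), read by MTT assay, with a stated time of 72 h; a lower number here means a stronger inhibitor, a higher number a weaker inhibitor:
- Compound 1 `Nc1nc(N)c2c(-c3cc4ccccc4o3)cn([C@@H]3O[C@H](CO)[C@@H](O)[C@H]3O)c2n1`: 18600 nM
- Compound 2 `Cc1nc(N)c2c(-c3ccoc3)cn([C@@H]3O[C@H](CO)[C@@H](O)[C@H]3O)c2n1`: > 20000 nM, a limit
- Compound 3 `Cc1nc(N)c2c(-c3ccccc3)cn([C@@H]3O[C@H](CO)[C@@H](O)[C@H]3O)c2n1`: > 20000 nM, a limit

Compound 3 has no number, only a limit of > 20000 nM. The series presses against (the limit of > 20000 nM in this assay, at which 2 of the 3 values shown sit). For the measured compounds named here, the one measured step that touches compound 3 is a step that the two limits leave unreadable from compound 2 to compound 3, so it gives no size to carry forward.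

Compound 4 `Cc1nc(N)c2c(-c3cc4ccccc4o3)cn([C@@H]3O[C@H](CO)[C@@H](O)[C@H]3O)c2n1` follows from compound 3 by placing 1-benzofuran-2-yl in place of phenyl on an aromatic carbon. Going by the values given here, no measured step shows this exchange. The nearest guide is compound 1, which carries the same 1-benzofuran-2-yl group on a core that is not identical and gives a real number, 18600 nM. On that single value, a modest shift toward stronger inhibition in this assay is expected, though compound 4 may well stay at the limit. The expected change is an at least 1.1-fold lower number from compound 3 to compound 4 (0.04 log units; that floor lies within the scatter). For compound 4 the estimate is 18000 nM, with an expected range from 8000 nM to 40000 nM.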

Compound 4, half-maximal inhibitory concentration: 15700 nM
Beside the measured number, compound 4's estimate is 1.1-fold (0.06 log units) above it; measured number inside the range.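

In this assay, 1-benzofuran-2-yl on this aromatic carbon gives compound 4 a measured number, whereas furan-3-yl and phenyl on the same methyl-bearing core give only limits: the limit of > 20000 nM in this assay, at which 2 of the 4 values shown sit. The exchanges read as an at least 1.2-fold lower number from compound 3 to compound 4 (0.10 log units; that floor lies within the scatter) and an at least 1.2-fold lower number from compound 2 to compound 4 (0.10 log units; that floor lies within the scatter), so each shows a direction but only a floor on its size. With 1-benzofuran-2-yl held fixed, the other exchange, methyl in place of amino, reads as a 1.2-fold lower number from compound 1 to compound 4 (0.07 log units; within the scatter), so it shows no separable effect on the number.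

The compounds shown leave open whether amino in place of methyl would give a number with furan-3-yl or phenyl on this carbon. They also leave open how an amine, a carboxylic acid or a longer chain on this carbon would compare with 1-benzofuran-2-yl.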